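Ring size at the urea nitrogen: from compound 2 to compound 4

This account rests on a few compounds, and the source may have more. Where it says the series, first, only, none or still open, it means among the compounds named here.

Compound 1 `O=C(NCCCOc1ccc2nc(O)ccc2c1)N(C1CCCCC1)C1CC1`: 100%
Compound 2 `O=C(NCCCOc1ccc2nc(O)ccc2c1)N(C1CC1)[C@@H]1CCC[C@H]1O`: 67%
Compound 3 `O=C(NCCCOc1ccc2[nH]c(=O)ccc2c1)N(C1CC1)[C@@H]1CCCC[C@H]1O`: 100%; 100% (2 entries)

In a functional assay on the whole organism for inhibition, with Mus musculus as the target, at a dose of 30 mg/kg by the oral route (on this read-out higher numbers stand for more inhibition at the one dose given (going by the name of the read-out) and lower numbers for less inhibition), compound 2 stands lowest of the two single numbers, and its nearest neighbour, compound 1, gives 100%. Compound 3 contributes two entries but no single number. Within the data shown here, the only step measured in one place is the one from cyclohexyl to 2-hydroxycyclopentyl on the amide-type nitrogen, which gave a number 33 percentage points lower from compound 1 to compound 2 (beyond the scatter).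

Compound 4 `O=C(NCCCOc1ccc2nc(O)ccc2c1)N(C1CC1)[C@@H]1CCCCC[C@H]1O` has not yet been measured in this assay. It differs from compound 2 in one place: 2-hydroxycycloheptyl in place of 2-hydroxycyclopentyl on an amide-type nitrogen. Among the measured compounds shown here, no measured step covers this exact change. The measured step from compound 1 to compound 2 was large, and compound 3, which carries a six-membered hydroxylated ring at the same nitrogen but also differs elsewhere, gives 100%; 100% (2 entries). Taken together these suggest that the smaller five-membered ring in compound 2 sits at the weak end, and that a larger ring may bring the number back toward that of compound 1. The step is therefore expected to be upward, with a number 18 percentage points higher from compound 2 to compound 4 (beyond the scatter) as the estimate. Compound 4 is expected to give about 85%, within the range 55% to 100%.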

Compound 4, a percentage reported as inhibition, in the whole organism at one dose (the size of the read-out at that dose, not a potency): 44%
Compound 4: middle estimate off by 41 percentage points, on the high side, and the stated range ends above it.
By their numbers in this assay, from the lowest: compound 4; then compound 2; then compound 1.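

In this assay, enlarging the hydroxylated ring on the amide-type nitrogen did not recover the inhibition seen with the cyclohexyl group: 2-hydroxycycloheptyl in place of 2-hydroxycyclopentyl gave a number 23 percentage points lower from compound 2 to compound 4 (beyond the scatter). The seven-membered ring thus moved the read-out further from compound 1 , not towards it, and 2-hydroxycycloheptyl in place of cyclohexyl gave a number 56 percentage points lower from compound 1 to compound 4 (beyond the scatter). This position therefore responds to the change of ring, and among compound 1 , compound 2 and compound 4 the two hydroxylated rings both stand below the plain cyclohexyl group, with the seven-membered ring lowest of all.

The compounds shown do not separate the part played by ring size from that played by the hydroxyl group, so it remains open how a plain cycloheptyl group or a 2-aminocycloheptyl group would read at this nitrogen, and all these numbers come from a single dose. Nothing measured here accounts for the fall in inhibition.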